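The source may hold more compounds than are shown below. What is called first, only, known or untested is meant among the compounds shown, and "the series" means these compounds.

Compounds measured in a functional assay on MDA-MB-231 cells (Homo sapiens) for cytotoxicity, read by MTT assay, with a stated time of 72 h; a higher number here means a weaker inhibitor, a lower number a stronger inhibitor:
compound 1 `CC1(C)O[C@@H](CO)[C@H](Cn2cc(Cn3c4c(c5ccccc53)C(=O)c3c[n+]([O-])c5ccccc5c3C4=O)nn2)O1` — 680 nM
compound 2 `O=C1c2c[n+]([O-])c3ccccc3c2C(=O)c2c1c1ccccc1n2CCCCN1CCCCC1` — 610 nM
compound 3 `CN(C)CCCCCn1c2c(c3ccccc31)C(=O)c1c[n+]([O-])c3ccccc3c1C2=O` — 240 nM

Compound 1 gives the highest number of the three in this assay; compound 2 sits within the scatter of it, while compound 3 lies beyond the scatter, at a lower number. Within the data shown here, the single measured step, a 2.5-fold lower number from compound 2 to compound 3 (0.41 log units; beyond the scatter), concerns the amine at the end of the chain on the shared core and has no counterpart in the change now followed.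

Compound 4 `O=C1c2c[n+]([O-])c3ccccc3c2C(=O)c2c1c1ccccc1n2Cc1cn([C@@H]2O[C@H](CO)[C@@H](O)[C@H](O)[C@H]2O)nn1` differs from compound 1 by 3,4,5-trihydroxy-6-(hydroxymethyl)oxan-2-yl in place of (5-(hydroxymethyl)-2,2-dimethyl-1,3-dioxolan-4-yl)methyl on an aromatic nitrogen. Among the measured compounds shown here, no measured step touches this part of the molecule, so nothing here argues for a shift beyond the scatter in this assay in either direction. Compound 4 is therefore expected near the parent, with a step of a 1.0-fold higher number from compound 1 to compound 4 (0.01 log units; within the scatter), giving an estimate of 700 nM in this assay, within 300 nM to 1600 nM.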

Compound 4, half-maximal inhibitory concentration: 650 nM
Compound 4: the middle estimate sits 1.1-fold (0.03 log units) above what was measured; measured number inside the range.
By their numbers in this assay, from the lowest: compound 3; then compounds 2, 4 and 1 (each within the scatter of the next).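

In this assay, putting 3,4,5-trihydroxy-6-(hydroxymethyl)oxan-2-yl in place of (5-(hydroxymethyl)-2,2-dimethyl-1,3-dioxolan-4-yl)methyl on the aromatic nitrogen gives a 1.0-fold lower number from compound 1 to compound 4 (0.02 log units; within the scatter), even though the count of hydrogen-bond donors goes from 1 to 4 and the five-membered ring becomes six-membered. At this position, these two quite different groups cannot be told apart in this read-out. Nothing available accounts for this result. The compounds shown leave open whether a carboxylic acid, or an amine like the one ending the chain of compound 3, would move the number if placed on that nitrogen.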